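Swapping an aromatic amide substituent for a saturated ring

The compounds below may be only part of what the source reports. "The series", "measured", "known", "first", "only" and "open" are said of these compounds alone.

Measured compounds:
compound 1 `Cc1cc(NC(=O)CN2CCC(c3cccc[n+]3[O-])CC2)ccc1F` gives 75%
compound 2 `C=Cc1cccc(C(=O)NCN2CCC(c3cccc[n+]3[O-])CC2)c1` gives 63%
compound 3 `Cc1cccc(NC(=O)CN2CCC(c3ccccc3)CC2)c1` gives 37%

In a functional assay on HEK293 cells for agonist activity at D(4) dopamine receptor (Homo sapiens), read by FLIPR (a higher number here means a larger maximal response, a lower number a smaller maximal response), compound 1 stands highest of the three, with compound 2 next, a gap beyond the usual scatter, and compound 3 furthest, well beyond it. The not yet measured compound 4 `O=C(CN1CCC(c2cccc[n+]2[O-])CC1)NC1CCCCC1` keeps the core of compound 1 and differs in one place: cyclohexyl in place of 4-fluoro-3-methylphenyl on an amide-type nitrogen. Within the data shown here, no measured pair shows this kind of change, so the size of its effect is unknown. A moderate fall is expected, since the replacement of an aromatic ring by a non-aromatic one is a marked change, and the expected step is a number 20 percentage points lower from compound 1 to compound 4 (beyond the scatter). Compound 4 is estimated at 55%, with a range from 30% to 80%.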

Compound 4, largest response reached (reported as efficacy), in percent of the reference or control that the assay uses: 58%
For compound 4 the middle estimate is 3 percentage points below the measured one, within the range that was stated.
By their numbers in this assay, from the lowest: compound 3; then compounds 4 and 2 (each within the scatter of the next); then compound 1.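

In this assay, cyclohexyl in place of 4-fluoro-3-methylphenyl on the amide-type nitrogen gives a number 17 percentage points lower from compound 1 to compound 4 (beyond the scatter). An aromatic ring at this position is therefore not required for a sizeable response, since compound 4 still reaches 58%, though the change carries a real, modest cost. No data on hand explain this fall.

The compounds shown leave open whether the loss follows from the ring no longer being aromatic or from the missing fluorine and methyl. As far as these compounds go, how a smaller ring such as cyclopropyl, an open chain such as n-butyl, or a cyclohexyl carrying an amine would fare at this position also remains open.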